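Isopropyl to methyl on a sulfonyl sulfur: working notes

The source may hold more compounds than are shown below. What is called first, only, known or untested is meant among the compounds shown, and "the series" means these compounds.

Measured in an in vivo ADME assay on the whole organism (strain BALB/c) for pharmacokinetics, with Mus musculus as the target, read by LC-MS, at a dose of 5 mg/kg by the oral route; on this read-out higher numbers stand for higher oral bioavailability and lower numbers for lower oral bioavailability:
- compound 1 `CC(C)S(=O)(=O)c1ccc(Cl)c(C#Cc2cc(Cl)ccc2OCC(=O)O)c1`: 64%
- compound 2 `Cc1ccc(S(=O)(=O)N2CCOCC2)cc1C#Cc1cc(Cl)ccc1OCC(=O)O`: 48%

Compound 1 holds the higher of the two numbers, and compound 2 stands lower by more than the usual scatter. These two compounds differ in more than one place, and their gap gives no size for a single change. The next compound to be read is compound 3 `CS(=O)(=O)c1ccc(Cl)c(C#Cc2cc(Cl)ccc2OCC(=O)O)c1`, which keeps the core of compound 1 and carries methyl in place of isopropyl on a sulfonyl sulfur. Among the compounds with values here, no step between measured compounds bears on this change. The expectation rests on compound 1 at 64% alone. A small downward move in this assay is expected, most likely not beyond the scatter. The estimated change is a number 6 percentage points lower from compound 1 to compound 3 (within the scatter). Within the data shown here, the range is kept wide: only two numbers exist so far. The estimate for compound 3 is 58%, with an expected range of 38% to 78%.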

Compound 3, oral bioavailability: 141%
Beside the measured number, compound 3's estimate is 83 percentage points below it; measured number above the stated range.
By their numbers in this assay, from the lowest: compound 2; then compound 1; then compound 3.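

In this assay the series now has its first step at a single place, and it is a large one: a number 77 percentage points higher from compound 1 to compound 3 (beyond the scatter). The group on a sulfonyl sulfur whose other neighbour is an aromatic carbon is therefore far from silent in this read-out, although the change only replaces isopropyl, with 3 heavy atoms, by methyl, with 1 heavy atom, and neither group brings a ring, a hydrogen-bond donor, a hydrogen-bond acceptor or a net charge. No measurement at hand bears on what lies behind this step.

Within the data shown here, the single step cannot show whether oral bioavailability follows the size of the group on the sulfur, as ethyl or cyclopropyl at this place could test, or whether methyl stands apart, and an amine on the same sulfur would extend the comparison beyond carbon groups. From the compounds shown here alone, it also remains open whether isopropyl to methyl gives a step of similar size on a core other than that of compound 1.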